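Clearance across piperazine and piperidine substituents on the shared core

The compounds below may be only part of what the source reports. "The series", "measured", "known", "first", "only" and "open" are said of these compounds alone.

Compound 3 `COc1cc2nnc(C(N)=O)c(Nc3ccc(C)cc3F)c2cc1N1CCC(OC)CC1` stands highest of the three numbers in an ADME assay on the whole organism for pharmacokinetics, with Rattus norvegicus as the target, at a dose of 10 mg/kg by the oral route (on this read-out lower numbers stand for slow clearance and higher numbers for fast clearance), giving 58 mL/min/kg. Compound 1 `COc1cc2nnc(C(N)=O)c(Nc3ccc(C)cc3F)c2cc1N1CCN(C(C)C)CC1` gives 17 mL/min/kg, and compound 2 `COc1cc2nnc(C(N)=O)c(Nc3ccc(C)cc3F)c2cc1N1C[C@@H](C)N[C@@H](C)C1` gives 4 mL/min/kg. Going by the values given here, the steps that bear on the next compound are a 3.4-fold higher number from compound 1 to compound 3 (0.53 log units; beyond the scatter) and a 15-fold higher number from compound 2 to compound 3 (1.16 log units; beyond the scatter). Compound 4 `COc1cc2nnc(C(N)=O)c(Nc3ccc(C)cc3F)c2cc1N1CCN(S(C)(=O)=O)CC1` carries the change (4-(methylsulfonyl)piperazin-1-yl in place of 4-methoxypiperidin-1-yl on an aromatic carbon), again trading the 4-methoxypiperidin-1-yl group of compound 3 for a piperazin-1-yl group bearing a different substituent. Both measured exchanges of that kind ran the other way, one modest and one large, so for compound 4 a lower number in this assay is expected, of a size between those two steps, namely a 3.9-fold lower number from compound 3 to compound 4 (0.59 log units; beyond the scatter). Compound 4 is accordingly estimated at 15 mL/min/kg, with a range from 5 mL/min/kg to 45 mL/min/kg.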

Compound 4, clearance: 22 mL/min/kg
Compound 4: the middle estimate sits 1.5-fold (0.17 log units) below what was measured; low and high end bracket the measured number.
By their numbers in this assay, from the lowest: compound 2; then compounds 1 and 4 (each within the scatter of the next); then compound 3.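

Going by these compounds alone, compound 4 gives the first exchange on the ring amine nitrogen itself: methylsulfonyl in place of isopropyl yields in this assay (a step of a 1.3-fold higher number from compound 1 to compound 4 (0.11 log units; within the scatter)), so this read-out does not separate these two substituents. The 4-(methylsulfonyl)piperazin-1-yl group still stands apart from both other groups at this position on the aromatic carbon (a 2.6-fold lower number from compound 3 to compound 4 (0.42 log units; beyond the scatter); a 5.5-fold higher number from compound 2 to compound 4 (0.74 log units; beyond the scatter)). Nothing measured on these compounds accounts for these differences.

Open, from the compounds shown here alone, is whether an unsubstituted piperazine or an acetyl group on that nitrogen would read like compound 2 or like compound 4.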